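The source may report more compounds than this note shows. Statements on the series, on what has been measured and on what is new or still open speak of the compounds shown alone.

Measured so far:
compound 1 `C=C1C(=O)OC[C@H]1CCOC(=O)Nc1ccccc1`: 390 nM
compound 2 `C=C1C(=O)OC[C@@H]1CCOC(=O)Nc1c(C)cccc1C(C)C`: 5980 nM
compound 3 `C=C1C(=O)OC[C@@H]1CCOC(=O)Nc1ccccc1F`: 690 nM

In a functional assay on RAW264.7 cells (Mus musculus) for inhibition, with a stated time of 30 min (a higher number here means a weaker inhibitor, a lower number a stronger inhibitor), compound 2 gives the highest of the three numbers. Compound 3 gives a lower number and compound 1 a lower one still; both gaps lie beyond the usual scatter. Compound 4 `C=C1C(=O)OC[C@H]1CCOC(=O)Nc1c(C)cccc1C(C)C` is next. How it differs from compound 2: the two compounds have the same atoms and bonds and differ only in configuration as drawn: 1 of 1 stereo elements differ; a stereocentre at a saturated ring carbon is drawn R in compound 2 and S in compound 4. Among the compounds with values here, no measured pair differs only in configuration, so there is no measured step of this kind to lean on. Compound 1 and compound 3 are drawn with opposite configurations yet both sit far below compound 2, so the drawn configuration alone is not expected to move the number much; the step from compound 2 to compound 4 is expected to be small, likely within the scatter, at a 1.3-fold lower number from compound 2 to compound 4 (0.12 log units; within the scatter). Compound 4 is expected to give 4500 nM, with a range from 1500 nM to 13000 nM.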

Compound 4, half-maximal inhibitory concentration: 1940 nM
For compound 4 the middle estimate is 2.3-fold (0.37 log units) above the measured one; the range from low to high includes it.
By their numbers in this assay, from the lowest: compounds 1 and 3 (each within the scatter of the next); then compound 4; then compound 2.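

In this assay, within the data shown here, the stereocentre at the saturated ring carbon does move the number, with a 3.1-fold lower number from compound 2 to compound 4 (0.49 log units; beyond the scatter), and this is the first measured step of its kind. The S drawing gives the lower number in this one pair. The step can be assigned to the stereocentre alone because nothing else changes: the fact that compounds 2 and 4 differ only in the configuration as drawn

As far as these compounds go, whether the S drawing also gives the lower number with the other substituents stays open. So does the outcome of replacing the methyl and isopropyl groups with an amine or a carboxylic acid.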